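This account rests on a few compounds, and the source may have more. Where it says the series, first, only, none or still open, it means among the compounds named here.

Of the compounds shown here, three built on one shared core have been tested in a functional assay on HEK293 cells for agonist activity at Bombesin receptor subtype-3 (Homo sapiens), read by luminescence and calcium flux, with a stated time of 10 min; on this read-out higher numbers stand for an effect only at larger amounts of compound and lower numbers for an effect already at smaller amounts. Compound 1 `CCC(C)(C)Cc1c[nH]c(CCc2ccc(-c3cccc(N)n3)cc2)n1` gives 97 nM. Compound 2 `CCC(C)(C)Cc1c[nH]c(CCc2ccc(-c3cccnc3)cc2)n1` gives 98 nM. Compound 3 `CCC(C)(C)Cc1c[nH]c(CCc2ccc(-c3cnsc3)cc2)n1` gives 100 nM. The three numbers sit side by side: a 1.0-fold higher number from compound 1 to compound 2 (0.00 log units; within the scatter), a 1.0-fold higher number from compound 1 to compound 3 (0.01 log units; within the scatter) and a 1.0-fold higher number from compound 2 to compound 3 (0.01 log units; within the scatter). Compound 3 therefore stands together with compounds 1 and 2, its number within the scatter of both, and none of the three can be called apart from the others in this assay.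

Compound 4 `CCC(C)(C)Cc1c[nH]c(CCc2ccc(-c3ccns3)cc2)n1` has not yet been measured in this assay. It differs from compound 3 in one place: 1,2-thiazol-5-yl in place of 1,2-thiazol-4-yl on an aromatic carbon. The same atoms are present in both, joined differently within the five-membered aromatic ring, and the rest of the molecule is unchanged. Going by the values given here, the steps that bear on this change are the three exchanges of the aromatic group at this place among compounds 1, 2 and 3, each of which left the number within the scatter. On that basis the expected step is no change at the digits printed from compound 3 to compound 4 (within the scatter), with no direction beyond the scatter. Compound 4 is expected to give 100 nM in this assay, with a range from 50 nM to 200 nM.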

Compound 4, half-maximal effective concentration: 102 nM
Estimate against measurement, compound 4: 1.0-fold (0.01 log units) below, and the stated range covers the measured number.
By their numbers in this assay, from the lowest: compounds 1, 2, 3 and 4 (each within the scatter of the next).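

Exchanging 1,2-thiazol-4-yl for 1,2-thiazol-5-yl changes only how the same atoms are joined within the five-membered aromatic ring, and a 1.0-fold higher number from compound 3 to compound 4 (0.01 log units; within the scatter) shows that in this assay this rearrangement, on an aromatic carbon para to a large group, can be made without moving the number beyond the scatter; the earlier compounds had shown this only for exchanges between different aromatic groups. The new group also stands level with both six-membered groups, with a 1.0-fold higher number from compound 2 to compound 4 (0.02 log units; within the scatter) and a 1.1-fold higher number from compound 1 to compound 4 (0.02 log units; within the scatter) both printed as within the scatter, so all four aromatic groups at this position remain indistinguishable on this read-out. No measurement is available that would account for this lack of difference.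

From the compounds shown here alone, all four groups at this position are aromatic rings, so it remains open whether a carboxylic acid, a primary amine or a morpholine in their place would leave the number unchanged. Going by these compounds, it also remains open whether the four compounds would stay this close if the shared core carried a longer chain, or if they were compared on any other read-out.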